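Nitro for Methyl on the Sulfonyl Aryl Ring

The compounds below may be only part of what the source reports. "The series", "measured", "known", "first", "only" and "open" are said of these compounds alone.

Three compounds of one series were tested in a functional assay on SMMC-7721 cells (Homo sapiens) for cytotoxicity, read by MTT assay, with a stated time of 24 h; on this read-out lower numbers stand for stronger inhibition and higher numbers for weaker inhibition. Compound 1, with the structure `Cc1ccc(S(=O)(=O)N2C/C(=C\c3ccncc3)C(=O)/C(=C/c3ccccc3F)C2)cc1`, gives 13200 nM in this assay. Compound 2, `O=C1/C(=C/c2ccncc2)CN(S(=O)(=O)c2ccc([N+](=O)[O-])cc2)C/C1=C\c1ccccc1F`, carries the change nitro in place of methyl on an aromatic carbon and gives 15800 nM in this assay; the step is a 1.2-fold higher number from compound 1 to compound 2 (0.08 log units; within the scatter). Compound 3, `Cc1ccc(S(=O)(=O)N2C/C(=C\c3cccnc3)C(=O)/C(=C/c3ccccc3C(F)(F)F)C2)cc1`, differs from compound 1 in its core, and the difference between the two cores is not broken down here; in this assay compound 3 gives 6700 nM. Its number is the lowest of the three, but its gap to compound 1 lies within the scatter, so no order between compound 3 and compound 1 is claimed; only its gap to compound 2 lies beyond the scatter.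

Compound 4, `O=C1/C(=C/c2cccnc2)CN(S(=O)(=O)c2ccc([N+](=O)[O-])cc2)C/C1=C\c1ccccc1C(F)(F)F`, has not been measured. Among the measured compounds shown here, it stands to compound 3 as compound 2 stands to compound 1: the change is nitro in place of methyl on an aromatic carbon, and it is the same change as the one from compound 1 to compound 2, at the same place. Compound 4 is therefore expected to sit close to compound 3, with a step of a 1.2-fold higher number from compound 3 to compound 4 (0.08 log units; within the scatter), because the step of a 1.2-fold higher number from compound 1 to compound 2 (0.08 log units; within the scatter) stayed within the scatter when this change was made on the core of compound 1. For compound 4 the estimate in this assay is 8000 nM, with a range from 4000 nM to 16000 nM.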

Compound 4, half-maximal inhibitory concentration: 15900 nM
Compound 4: the middle estimate sits 2.0-fold (0.30 log units) below what was measured, within the range that was stated.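

On the core of compound 3, the change from methyl to nitro gives a 2.4-fold higher number from compound 3 to compound 4 (0.38 log units; beyond the scatter) in this assay, whereas the same change on the core of compound 1 stayed within the scatter. Set side by side, however, the two steps cannot be told apart: the same change on two cores in this assay, a 1.2-fold higher number (0.08 log units; within the scatter) from compound 1 to compound 2 and a 2.4-fold higher number (0.38 log units; beyond the scatter) from compound 3 to compound 4, 2.0-fold (0.30 log units) apart, within the scatter of two such steps. Among the compounds shown here, the pair therefore shows that the result on one core is compatible with the result on the other, but it does not show that the core alters the size of the step, even though only one of the two steps lies beyond the scatter on its own; nor does it show that the step keeps a fixed size, since two cores are too few to establish either reading.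

The compounds shown leave open how the step would read on further cores of the series, and whether the two steps would stay inseparable with more pairs of this kind. They also leave open what an amine, a carboxylic acid or a longer chain would give in place of the methyl of the (4-methylphenyl)sulfonyl group, on either core, and whether any such group would separate the two cores more clearly in this assay.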